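A few compounds are considered here, and "the series" means these few. Any claim that something is new, unique, unknown or untested is made for them only; others in the source may bear on it.

Measured so far:
- compound 1, `Cc1ccccc1OS(=O)(=O)c1cccc(NC(=O)NCCCCl)c1`: 29000 nM
- compound 2, `CCc1ccccc1OS(=O)(=O)c1cccc(NC(=O)NCCCCl)c1`: 24000 nM
- compound 3, `CCNC(=O)Nc1ccc(S(=O)(=O)Nc2ccccc2CC)cc1`: 90000 nM

In a functional assay on M21 cells (Homo sapiens) for cytotoxicity, read by sulforhodamine B assay, with a stated time of 48 h (a lower number here means a stronger inhibitor, a higher number a weaker inhibitor), compound 1 gives 29000 nM. Compound 2 carries the change methyl in place of hydrogen on a saturated chain carbon bound to an aromatic carbon and gives 24000 nM, so that the step of a 1.2-fold lower number from compound 1 to compound 2 (0.08 log units; within the scatter). Compound 3 stands on a different core; the difference between the two cores is not broken down here. In this assay compound 3 gives 90000 nM, which sets it apart from both compound 1 and compound 2.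

Compound 4, `CCCc1ccccc1NS(=O)(=O)c1ccc(NC(=O)NCC)cc1`, has not yet been measured. It differs from compound 3 by methyl in place of hydrogen on a saturated chain carbon, two bonds along the chain from an aromatic carbon. For the measured compounds named here, this is the same kind of change as the one from compound 1 to compound 2, but the place differs: there the methyl entered on a saturated chain carbon bound to an aromatic carbon, here on a saturated chain carbon two bonds along the chain from an aromatic carbon. Because a 1.2-fold lower number from compound 1 to compound 2 (0.08 log units; within the scatter) stayed within the scatter, a step of about a 1.2-fold lower number from compound 3 to compound 4 (0.08 log units; within the scatter) is expected here as well. Compound 4 is therefore expected to give about 75000 nM in this assay, between 30000 nM and 200000 nM.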

Compound 4, half-maximal inhibitory concentration: 41000 nM
Beside the measured number, compound 4's estimate is 1.8-fold (0.26 log units) above it; the measured number falls inside the stated range.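

In this assay the added methyl gave a 2.2-fold lower number from compound 3 to compound 4 (0.34 log units; beyond the scatter) while the same kind of change, at a different place on the core of compound 1, gave a 1.2-fold lower number from compound 1 to compound 2 (0.08 log units; within the scatter) and the two steps cannot be told apart: the same change on two cores in this assay, a 1.2-fold lower number (0.08 log units; within the scatter) from compound 1 to compound 2 and a 2.2-fold lower number (0.34 log units; beyond the scatter) from compound 3 to compound 4, 1.8-fold (0.26 log units) apart, within the scatter of two such steps

The change therefore carried from one core to the other without a detectable difference in the size of its step. This rests on a single pair on each core, so it does not show that the step is identical on both cores or that it would hold on any further core.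

The compounds shown leave open whether a butyl chain, or a chain carrying an amine or a carboxylic acid, would continue this step on either core.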